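Reversing an amide back to a urea with a smaller acid

The source may hold more compounds than are shown below. What is called first, only, known or untested is meant among the compounds shown, and "the series" means these compounds.

Compounds measured so far:
compound 1, `CC(C)(NC(=O)Nc1ccc(F)c(C(F)(F)F)c1)C(=O)O`, > 100 ug/mL in a physicochemical assay for solubility, read by nephelometry, in phosphate buffer, measured as kinetic solubility, at pH 6.5, tested at 10 mg/mL (a lower number here means a less soluble compound, a higher number a more soluble compound), a value that is a limit of this assay and not a number
compound 2, `CC(C)(NC(=O)Nc1ccccc1)C(=O)O`, 50 ug/mL
compound 3, `CC(C)(CC(=O)Nc1ccc(F)c(C(F)(F)F)c1)C(=O)O`, 25 ug/mL

Compound 3 has the lowest of the two numbers shown, and its nearest neighbour is compound 2, whose value lies within the usual scatter of it. Going by the values given here, the one measured step is an at least 4.0-fold lower number from compound 1 to compound 3 (0.60 log units; beyond the scatter), and compound 1 sits at the limit described by the limit of > 100 ug/mL in this assay, at which 1 of the 3 values shown sits, so the true size of that step is not known.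

Compound 4 is `O=C(O)CNC(=O)Nc1ccc(F)c(C(F)(F)F)c1`. It differs from compound 3 in one place: (carboxymethyl)amino in place of 2-carboxy-2-methylpropyl on a carbonyl carbon. This change puts the urea linkage of compound 1 back in place, with a shorter acid chain on it. The step from compound 1 to compound 3 therefore bears on it in reverse, and a rise back toward the range of compound 1 is expected. Compound 4 is estimated at 100 ug/mL, between 40 ug/mL and 200 ug/mL. The expected step is a 4.0-fold higher number from compound 3 to compound 4 (0.60 log units; beyond the scatter).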

Compound 4, solubility: > 100 ug/mL
Compound 4 gave a limit, no number; the forecaster's own chance of this, stated with the estimate: 55%; the middle value lies on the limit itself.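

At this place on the carbonyl carbon, (carboxymethyl)amino in place of 2-carboxy-2-methylpropyl gives an at least 4.0-fold higher number from compound 3 to compound 4 (0.60 log units; beyond the scatter) in this assay. Compound 4 gives > 100 ug/mL, which is a limit of the assay and not a number. The gap from compound 3 seen earlier with compound 1 therefore does not depend on 1-carboxy-1-methylethyl, since the smaller carboxymethyl on the amide-type nitrogen also gives a clear step up from compound 3.

The step from compound 1 to compound 4 cannot be read, and the two acid chains cannot be ranked, because both values are limits: the limit of > 100 ug/mL in this assay, at which 2 of the 4 values shown sit. Also open, as far as these compounds go, is whether a longer chain on the amide-type nitrogen, or an amine in place of the carboxylic acid, would keep the number clear of compound 3.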